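Swapping the Amine Tail of Compound 1 for an Ester-Bearing Chain

The compounds below may be only part of what the source reports. "The series", "measured", "known", "first", "only" and "open" are said of these compounds alone.

Compound 1, `CCn1c(C(=O)NCCCN(C)C)ccc1C(CC)(CC)c1ccc(OCCC(O)(CC)CC)c(C)c1`: 5 nM in an assay on cells for agonist activity at vitamin D3 receptor (Homo sapiens), with a stated time of 96 h; on this read-out lower numbers stand for an effect already at smaller amounts and higher numbers for an effect only at larger amounts of compound
Compound 2, `CCn1c(C(=O)NCC#N)ccc1C(CC)(CC)c1ccc(OCCC(O)(CC)CC)c(C)c1`: 1080 nM in this assay
Compound 3, `C=CCN(C)C(=O)c1ccc(C(CC)(CC)c2ccc(OCCC(O)(CC)CC)c(C)c2)n1CC`: in this assay compound 3 gives only a limit, > 10000 nM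

Compound 1 has the lowest of the two numbers that were actually read out. Its nearest neighbour is compound 2, reached by a 220-fold higher number from compound 1 to compound 2 (2.33 log units; beyond the scatter). Compound 3 did not yield a number at all but sits at the limit of this assay (the limit of > 10000 nM in this assay, at which 1 of the 3 values shown sits).

Compound 4, `CCC(C)C(NC(=O)c1ccc(C(CC)(CC)c2ccc(OCCC(O)(CC)CC)c(C)c2)n1CC)C(=O)OC`, has not yet been measured in this assay. It differs from compound 1 by a group of 9 heavy atoms (7 carbon, 2 oxygen; no ring) in place of a group of 6 heavy atoms (5 carbon, 1 nitrogen; no ring), on an amide-type nitrogen. Among the measured compounds shown here, the change that bears on it most directly is the one from compound 1 to compound 2, where a cyano group replaced the 2-(dimethylamino)ethyl part of the chain on the same amide-type nitrogen and the number rose by a large step. The step from compound 1 to compound 3, an at least 2000-fold higher number from compound 1 to compound 3 (3.30 log units; beyond the scatter), was larger still, but it also altered the nitrogen itself. Compound 4 keeps the nitrogen as in compound 1 and compound 2 while losing the dimethylamino group, so a large rise in number is expected, though its exact size is uncertain.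

For compound 4 the expected value in this assay is 1500 nM, within a range from 200 nM to 10000 nM. This estimate corresponds to a 300-fold higher number from compound 1 to compound 4 (2.48 log units; beyond the scatter).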

Compound 4, half-maximal effective concentration: > 10000 nM
Compound 4: a limit, no number; the forecaster's own chance of this, stated with the estimate: 25%; middle value at least 6.6-fold (0.82 log units) from the limit.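

In this assay, putting the ester-bearing chain in place of the 3-(dimethylamino)propyl group on the amide-type nitrogen gives an at least 2000-fold higher number from compound 1 to compound 4 (3.30 log units; beyond the scatter), so keeping the amide hydrogen is not enough on its own to hold the low number of compound 1. The new chain also compares poorly with the much smaller cyanomethyl group, with an at least 9.2-fold higher number from compound 2 to compound 4 (0.96 log units; beyond the scatter), so a larger group on this nitrogen does not bring the number back down in the one case shown here. Compound 3 and compound 4 each give only a limit, so the step between them cannot be read, and two different groups on the carbonyl carbon end at the same limit: the limit of > 10000 nM in this assay, at which 2 of the 4 values shown sit.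

Compound 1 is the only compound shown whose chain ends in an amine, so it remains open whether the low number depends on that amine, on the length of the chain, or on both. A shorter or longer chain ending in dimethylamino, a plain propyl chain, or a chain ending in a carboxylic acid in place of the methyl ester would help to separate these possibilities.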